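Swapping a Fluorinated Four-Ring for an Oxygen Five-Ring

The compounds below may be only part of what the source reports. "The series", "measured", "known", "first", "only" and "open" are said of these compounds alone.

Measured so far in an ADME assay (Rattus norvegicus, strain Wistar Han) for metabolic stability; a lower number here means that the compound disappears faster, a higher number that the compound lasts longer:
compound 1 `CCn1c(-c2cnc(C)nc2)nc2c(N[C@H]3CCN(C(=O)C4CC(F)(F)C4)C3)ncnc21` gives 0.4 h
compound 2 `CCn1c(-c2cnc(C)nc2)nc2c(N[C@H]3CCN(C(=O)C4CCC4)C3)ncnc21` gives 0.6 h

Among these two numbers compound 1 stands at 0.4 h in this assay, with compound 2 the only neighbour; the step of a 1.5-fold higher number from compound 1 to compound 2 (0.18 log units; within the scatter) shows that the two sit within the usual scatter of one another, so neither can be called longer-lived.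

Compound 3 `CCn1c(-c2cnc(C)nc2)nc2c(N[C@H]3CCN(C(=O)C4CCOC4)C3)ncnc21` is not yet measured. It differs from compound 1 at the same place where compound 2 does: oxolan-3-yl in place of 3,3-difluorocyclobutyl on a carbonyl carbon. Going by the values given here, the only step that bears on this place is a 1.5-fold higher number from compound 1 to compound 2 (0.18 log units; within the scatter), which was too small to read as a real change. Among the compounds with values here, no measured step tells what the entering oxolan-3-yl, with its one hydrogen-bond acceptor, does here. The expectation for compound 3 in this assay is therefore a step of about a 1.3-fold higher number from compound 1 to compound 3 (0.10 log units; within the scatter), not beyond the scatter. Compound 3 is thus estimated at 0.5 h, within a range of 0.2 h to 1.2 h.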

Compound 3, half-life: 0.6 h
Beside the measured number, compound 3's estimate is 1.2-fold (0.08 log units) below it; measured number inside the range.
By their numbers in this assay, from the lowest: compounds 1, 2 and 3 (each within the scatter of the next).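

Putting oxolan-3-yl in place of 3,3-difluorocyclobutyl on the carbonyl carbon gives a 1.5-fold higher number from compound 1 to compound 3 (0.18 log units; within the scatter), and putting it in place of cyclobutyl gives no change at the digits printed from compound 2 to compound 3 (within the scatter). In this assay, then, a group carrying a ring oxygen and a hydrogen-bond acceptor, on a five-membered ring, cannot be told apart from either four-membered carbon ring, so all three compounds share one level of half-life within the scatter. No measurement shown here accounts for this sameness.

Still open, on these data alone, is whether an amine, a carboxylic acid or a longer chain on this carbonyl carbon would move the half-life beyond the scatter. The compounds shown also leave open whether any change at this place can do so, since all three keep the same remainder of the molecule.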